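The compounds below may be only part of what the source reports. "The series", "measured", "known", "first", "only" and "open" are said of these compounds alone.

Two compounds carry the shared core. Compound 1 `Cc1n[nH]c2ccc(-c3nc4cnc(N5CCN(C)CC5)cn4c3Nc3ccc(F)cc3)cc12` gives 0% in a functional assay on MV4-11 cells (Homo sapiens) for inhibition, with a stated time of 120 h, tested at 10 uM; on this read-out lower numbers stand for less inhibition and higher numbers for more inhibition at the one concentration tested (going by the name of the read-out). Compound 2 `COc1ccc(Nc2c(-c3ccc4[nH]nc(C)c4c3)nc3cnc(N4CCN(C)CC4)cn23)cc1OC` gives 6.27% in this assay and so stands highest of the two numbers shown, though only by a number 6.3 percentage points higher from compound 1 to compound 2 (within the scatter). Compound 3 `Cc1n[nH]c2ccc(-c3nc4cnc(N5CCN(C)CC5)cn4c3Nc3ccc(Cl)cc3Cl)cc12` is not yet measured and differs from compound 2 by 2,4-dichlorophenyl in place of 3,4-dimethoxyphenyl on a nitrogen on an aromatic ring. Going by the values given here, the one measured step, a number 6.3 percentage points higher from compound 1 to compound 2 (within the scatter), also exchanged this aryl group and stayed within the scatter. For compound 3 the expected step is therefore a number 2.3 percentage points lower from compound 2 to compound 3 (within the scatter), none beyond the scatter. Compound 3 is estimated at 4% in this assay, within -6% to 16%.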

Compound 3, a percentage reported as inhibition, at one concentration (the size of the read-out at that concentration, not a potency): 78.8%
For compound 3 the middle estimate is 74.8 percentage points below the measured one; measured number above the stated range.
By their numbers in this assay, from the lowest: compounds 1 and 2 (each within the scatter of the next); then compound 3.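

In this assay, the aryl group on this nitrogen proves to be far from a silent position: the change to 2,4-dichlorophenyl gives a number 72.5 percentage points higher from compound 2 to compound 3 (beyond the scatter) and a number 78.8 percentage points higher from compound 1 to compound 3 (beyond the scatter). The earlier exchange between 4-fluorophenyl and 3,4-dimethoxyphenyl had shown no step beyond the scatter, so this position responds to some aryl groups and not others.

On these data alone, whether both chlorines are required stays open, and 2-chlorophenyl, 4-chlorophenyl and 2,4-dimethylphenyl would each address this. No measurement at hand explains the jump.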